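The source may hold more compounds than are shown below. What is called first, only, known or untested is meant among the compounds shown, and "the series" means these compounds.

Measured compounds:
Compound 1 `COc1cc(/C=N/NC(=O)c2ccc(-c3nc4ccccc4s3)cc2)cc(OC)c1` gives 16200 nM in an assay on isolated protein for inhibition of Maltase-glucoamylase (Homo sapiens), with a stated time of 15 min; on this read-out higher numbers stand for weaker inhibition and lower numbers for stronger inhibition.
Compound 2 `COc1cc(/C=N/NC(=O)c2ccc(-c3nc4ccccc4s3)cc2)ccc1O` gives 53300 nM in this assay.

Among the compounds with values here, compound 2 stands at the higher of the two numbers; its only neighbour is compound 1, and the step of a 3.3-fold higher number from compound 1 to compound 2 (0.52 log units; beyond the scatter) lies beyond the scatter, so compound 2 is the weaker of the pair. Compound 3 `COc1ccc(/C=N/NC(=O)c2ccc(-c3nc4ccccc4s3)cc2)c(I)c1O` has not yet been measured. It differs from compound 2 in one place: 3-hydroxy-2-iodo-4-methoxyphenyl in place of 4-hydroxy-3-methoxyphenyl on a carbon with a double bond to nitrogen. Within the data shown here, the single measured step bears on it only loosely: it exchanged one substituted phenyl group for another at the same place and moved the number by a modest amount. Among the measured compounds shown here, the change to compound 3 again exchanges the substituted phenyl group and brings in an iodine, and no measured pair shows what an iodine does here. The step expected in this assay is therefore a 1.5-fold lower number from compound 2 to compound 3 (0.18 log units; within the scatter), with wide uncertainty in either direction. Compound 3 is estimated at 35000 nM in this assay, with a range from 9000 nM to 130000 nM.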

Compound 3, half-maximal inhibitory concentration: 44800 nM
Compound 3: the middle estimate sits 1.3-fold (0.11 log units) below what was measured, within the range that was stated.
By their numbers in this assay, from the lowest: compound 1; then compounds 3 and 2 (each within the scatter of the next).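

On the carbon with a double bond to nitrogen, 3-hydroxy-2-iodo-4-methoxyphenyl in place of 4-hydroxy-3-methoxyphenyl gives a 1.2-fold lower number from compound 2 to compound 3 (0.08 log units; within the scatter) in this assay, so a group carrying an iodine can stand here without a shift beyond the scatter. The gap to the 3,5-dimethoxyphenyl group remains, with a 2.8-fold higher number from compound 1 to compound 3 (0.44 log units; beyond the scatter), and among these three compounds both groups bearing a hydroxy and a methoxy give higher numbers than the group bearing two methoxy groups. Nothing available explains either step.

Going by these compounds, the group names show that the hydroxy and methoxy numbering also differs as the iodine enters, so the share of the iodine alone remains unknown. Also open, on these data alone, is how an amine or a carboxylic acid on this phenyl group would compare with these three.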